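Chlorine on the pendant phenyl and Vero cell cytotoxicity

This account rests on a few compounds, and the source may have more. Where it says the series, first, only, none or still open, it means among the compounds named here.

Compound 1, with the structure `CC1=CSC2=NC(/C=C/c3ccccc3)=C(C(=O)/C=C/c3ccccc3)C(c3ccccc3)N12`, was tested in an ADME assay on Vero cells (Chlorocebus sabaeus) for cytotoxicity, read by fluorescence and resazurin assay, with a stated time of 72 h (on this read-out lower numbers stand for higher toxicity in this test and higher numbers for lower toxicity in this test), where compound 1 gives 195 ug/mL. Compound 2, `CC1=CSC2=NC(/C=C/c3ccccc3Cl)=C(C(=O)/C=C/c3ccccc3Cl)C(c3ccccc3)N12`, gives 206 ug/mL in this assay, a number that sits within the scatter of the value for compound 1, so the two cannot be told apart. Compound 3, `CC1=CSC2=NC(/C=C/c3ccc(OCc4ccccc4)cc3)=C(C(=O)/C=C/c3ccc(OCc4ccccc4)cc3)C(c3ccccc3)N12`, reaches only a limit of the assay, > 500 ug/mL, and no number is known for it. Among the values shown, compound 1 thus holds the lowest of the two actual numbers, with compound 2 within the scatter of it and compound 3 at the limit of > 500 ug/mL in this assay, at which 1 of the 3 values shown sits.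

Compound 4, `CC1=CSC2=NC(/C=C/c3ccccc3)=C(C(=O)/C=C/c3ccccc3)C(c3ccc(Cl)cc3)N12`, has not yet been measured in this assay. Its difference from compound 1 is chloro in place of hydrogen on an aromatic carbon. No step between two measured compounds matches this change, so nothing shown gives the size of such a step. With compound 1 and compound 2 lying within the scatter of each other, the author expects for compound 4 a step from compound 1 that stays within the scatter, a 1.0-fold higher number from compound 1 to compound 4 (0.01 log units; within the scatter), in this assay. Compound 4 is therefore estimated at 200 ug/mL, with the likely range running from 100 ug/mL to 420 ug/mL.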

Compound 4, half-maximal cytotoxic concentration: 320 ug/mL
Beside the measured number, compound 4's estimate is 1.6-fold (0.20 log units) below it; the range from low to high includes it.
By their numbers in this assay, from the lowest: compounds 1, 2 and 4 (each within the scatter of the next). At a limit, above all of these: compound 3.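

In this assay, chloro in place of hydrogen on an aromatic carbon, the change from phenyl to 4-chlorophenyl on the shared core, gives a 1.6-fold higher number from compound 1 to compound 4 (0.22 log units; within the scatter). This is the only step shown between two compounds that differ in one place, and it gives the first direct reading for this position: the ring carries a chlorine without a shift that can be told from the usual scatter of the assay. Nothing shown gives a measured property that would account for the size of this step, so the numbers describe the step but offer no reason for it.

Going by these compounds, what remains open is whether this position tolerates other groups equally well, since a single chlorine says little about how a methoxy group, an amine, a carboxylic acid or a longer chain would read here in this assay. On these data alone, it is also open whether a chloro group at another place on this ring would stay within the scatter, and whether a step of this size would hold on a compound other than compound 1.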